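A few compounds are considered here, and "the series" means these few. Any claim that something is new, unique, unknown or untested is made for them only; others in the source may bear on it.

In a functional assay on MDA-MB-231 cells (Homo sapiens) for antiproliferative activity, read by MTT assay, with a stated time of 48 h (a lower number here means a stronger inhibitor, a higher number a weaker inhibitor), compound 1 `C=CS(=O)(=O)N1CCN(c2ncnc3sc(-c4cccc5ccccc45)cc23)CC1` gives 23700 nM and compound 2 `C=CS(=O)(=O)N1CCN(c2ncnc3sc(-c4ccnc(Cl)c4)cc23)CC1` gives 27700 nM. Compound 2 thus stands within the scatter of compound 1, the only other measured point in the series. Compound 3 `C=CS(=O)(=O)N1CCN(c2ncnc3sc(-c4ccc(OC)nc4)cc23)CC1` has not yet been measured. It differs from compound 2 as follows: 6-methoxypyridin-3-yl in place of 2-chloropyridin-4-yl on an aromatic carbon. Among the measured compounds shown here, only one measured step bears on this change, at the same place on the shared core, where 2-chloropyridin-4-yl replaced naphthalen-1-yl: a 1.2-fold higher number from compound 1 to compound 2 (0.07 log units; within the scatter). For the measured compounds named here, that single exchange of one aromatic group for another stayed within the scatter, but it is thin evidence, and no measured compound carries a methoxy group. No step beyond the scatter is therefore expected in this assay, and no direction is favoured. The expected step is a 1.1-fold lower number from compound 2 to compound 3 (0.03 log units; within the scatter). For compound 3 the estimated value is 26000 nM, with an expected range of 12000 nM to 50000 nM.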

Compound 3, half-maximal inhibitory concentration: 9270 nM
Compound 3: middle estimate off by 2.8-fold (0.45 log units), on the high side, and the stated range ends above it.
By their numbers in this assay, from the lowest: compound 3; then compounds 1 and 2 (each within the scatter of the next).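

In this assay, the aromatic group on this carbon next to the ring sulfur can shift the number beyond the scatter: 6-methoxypyridin-3-yl in place of 2-chloropyridin-4-yl gives a modest step (a 3.0-fold lower number from compound 2 to compound 3 (0.48 log units; beyond the scatter)), and in place of naphthalen-1-yl it gives another (a 2.6-fold lower number from compound 1 to compound 3 (0.41 log units; beyond the scatter)). Among the compounds shown here, the earlier exchange at this position stayed within the scatter, so compound 3 is the first sign that the position is not indifferent to the group it carries, and compound 3 has the lowest number of the three. Nothing measured here accounts for this step.

The change from compound 2 to compound 3 replaces chloro with methoxy and also moves the point of attachment on the pyridine, so the two cannot be separated. Going by these compounds, whether an amino group, a carboxylic acid or a longer ethoxy chain on the pyridine would lower the number further remains open.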